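The source may report more compounds than this note shows. Statements on the series, on what has been measured and on what is new or still open speak of the compounds shown alone.

Among the compounds with values here, in a functional assay on MIA PaCa-2 cells (Homo sapiens) for antiproliferative activity, read by sulforhodamine B assay, with a stated time of 48 h (a lower number here means a stronger inhibitor, a higher number a weaker inhibitor), compound 1 `COc1ccc2nc(-c3ccc(N/C=C\C(=O)c4ccc(OC)c(O)c4)c(C)c3)sc2c1` gives 17000 nM and compound 2 `COc1ccc2nc(-c3ccc(N/C=C\C(=O)c4ccc(OC)c(O)c4)cc3)sc2c1` gives 21900 nM, so compound 1 stands level with the only other measured compound. Compound 3 `COc1ccc2nc(-c3ccc(N/C=C\C(=O)c4ccc(OC)c(F)c4)c(C)c3)sc2c1` differs from compound 1 by fluoro in place of hydroxy on an aromatic carbon, with 3-hydroxy-4-methoxyphenyl becoming 3-fluoro-4-methoxyphenyl. Within the data shown here, the sole measured step, a 1.3-fold higher number from compound 1 to compound 2 (0.11 log units; within the scatter), removes a methyl and leaves the hydroxy untouched, so it bears only weakly on this change. No shift beyond the scatter is therefore expected in this assay, in either direction, though the uncertainty is wide. The estimated value for compound 3 is 15000 nM, with an expected range of 6000 nM to 38000 nM. The expected step is a 1.1-fold lower number from compound 1 to compound 3 (0.05 log units; within the scatter).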

Compound 3, half-maximal inhibitory concentration: 2300 nM
The estimate for compound 3 lay 6.5-fold (0.81 log units) above the measured number; measured number below the stated range.
By their numbers in this assay, from the lowest: compound 3; then compounds 1 and 2 (each within the scatter of the next).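

In this assay, fluoro in place of hydroxy on the 3-hydroxy-4-methoxyphenyl group gives a 7.4-fold lower number from compound 1 to compound 3 (0.87 log units; beyond the scatter), while the earlier step, a 1.3-fold higher number from compound 1 to compound 2 (0.11 log units; within the scatter), removed a methyl and stayed within the scatter. This place on the ring, ortho to a methoxy group, is thus the first shown to move the number, and the hydroxy is not required for activity here. Nothing measured here explains the gain. The compounds shown leave open whether it belongs to fluoro itself or to the loss of hydroxy, which chloro or plain hydrogen at this place could separate. They also leave open whether fluoro gives a similar step without the methyl of compound 1.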